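Butylpiperidinylmethyl benzodioxine esters at the serotonin-4 receptor

The source may hold more compounds than are shown below. What is called first, only, known or untested is meant among the compounds shown, and "the series" means these compounds.

Measured compounds:
compound 1 `CCCCN1CCC(COC(=O)c2ccc(NC)c3c2OCCO3)CC1` — 8.91 nM
compound 2 `CCCCN1CCC(COC(=O)c2cc(I)c(NC)c3c2OCCO3)CC1` — 20 nM

Going by the values given here, in an in vitro functional assay on HEK293/L9 cells for agonist activity at 5-hydroxytryptamine receptor 4 (Homo sapiens), read by cAMP accumulation (a higher number here means that more compound is needed for the effect, a lower number that less compound is needed), compound 2 gives 20 nM, the higher of the two numbers; the only neighbour is compound 1, and the step of a 2.2-fold higher number from compound 1 to compound 2 (0.35 log units; beyond the scatter) is modest but beyond the scatter. Compound 3 `CCCCN1CCC(COC(=O)c2cc(C#N)c(NC)c3c2OCCO3)CC1` has not been measured. It differs from compound 2 in one place: cyano in place of iodo on an aromatic carbon. Among the compounds with values here, no measured step exchanges iodo for cyano at this carbon; the single step that touches the position is a 2.2-fold higher number from compound 1 to compound 2 (0.35 log units; beyond the scatter), which shows that filling this carbon with iodo moved the number only modestly. Within the data shown here, with no step that bears directly on cyano, a change within the scatter or a modest one in either direction is expected, and the estimate stays near compound 2. Compound 3 is therefore expected at 15 nM in this assay, within 5 nM to 45 nM, meaning a step of a 1.3-fold lower number from compound 2 to compound 3 (0.12 log units; within the scatter).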

Compound 3, half-maximal effective concentration: 15.9 nM
Estimate against measurement, compound 3: 1.1-fold (0.03 log units) below, within the range that was stated.
By their numbers in this assay, from the lowest: compounds 1, 3 and 2 (each within the scatter of the next, the first and the last beyond it).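

In this assay, cyano in place of iodo on the aromatic carbon ortho to a methylamino group gives a 1.3-fold lower number from compound 2 to compound 3 (0.10 log units; within the scatter) and so leaves the two groups unseparated, although cyano brings two heavy atoms for one and a hydrogen-bond acceptor. From the hydrogen of compound 1, the cyano step reads a 1.8-fold higher number from compound 1 to compound 3 (0.25 log units; within the scatter) while the iodo step reads a 2.2-fold higher number from compound 1 to compound 2 (0.35 log units; beyond the scatter) and only the iodo step lies beyond the scatter, so this carbon now holds two unlike groups with at most a modest step from hydrogen. No supporting data offer a reason for this result.

On these data alone, whether the position stays this flat for a primary amine or a carboxylic acid remains open. Also open, as far as these compounds go, is whether iodo and cyano still read alike with a longer chain in place of butyl.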